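Methoxy in Place of Methyl: Expected Maximal Response

The compounds below may be only part of what the source reports. "The series", "measured", "known", "first", "only" and "open" are said of these compounds alone.

Measured compounds:
compound 1, `Cc1cc(NC(=O)Cn2nnc(-c3cccc(F)n3)n2)n(C2CCCCC2)n1`: in an assay on HEK293 cells for activation of Kir3.1/Kir3.2 (Homo sapiens), read by thallium flux (on this read-out lower numbers stand for smaller maximal responses and higher numbers for larger maximal responses), compound 1 gives > 83%, which is a limit of the assay.
compound 2, `Cc1ccc(-c2nnn(CC(=O)Nc3cc(C)nn3C3CCCCC3)n2)cc1`: in this assay compound 2 gives 86%.

Compound 2 holds the only number shown in this assay; the other value is a limit. The step that the limit leaves unreadable from compound 1 to compound 2 cannot be read because of the limit of > 83% in this assay, at which 1 of the 2 values shown sits. Compound 3, `COc1ccc(-c2nnn(CC(=O)Nc3cc(C)nn3C3CCCCC3)n2)cc1`, carries methoxy in place of methyl on an aromatic carbon, on an aromatic carbon of a six-membered aromatic ring of carbon only, para to a large group. No readable measured step bears on this change, so no step beyond the usual scatter is expected in this assay. Compound 3 is therefore expected to give 85% (range 70% to 100%), an expected step of a number 1 percentage points lower from compound 2 to compound 3 (within the scatter).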

Compound 3, largest response reached (Emax), in percent of the reference or control that the assay uses: 90%
Beside the measured number, compound 3's estimate is 5 percentage points below it; the range from low to high includes it.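

In this assay, among these compounds, methoxy in place of methyl on an aromatic carbon, para to a large group, gives the first readable step at this position: a number 4 percentage points higher from compound 2 to compound 3 (within the scatter). Between these two compounds, the exchange adds one oxygen and one hydrogen-bond acceptor without separating their maximal responses beyond the scatter. The step from compound 1 to compound 3 cannot be read because of the following: the limit of > 83% in this assay, at which 1 of the 3 values shown sits.

From the compounds shown here alone, whether an amine, a carboxylic acid or a longer alkoxy chain on this carbon would keep the response in this assay remains open.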